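The source may hold more compounds than are shown below. What is called first, only, known or untested is meant among the compounds shown, and "the series" means these compounds.

Three compounds share one core and have been run in an ADME assay on Caco-2 cells (Homo sapiens) for permeability, read by LC-MS, in the apical to basolateral direction, with a stated time of 60 min, at pH 6.5; on this read-out higher numbers stand for higher permeability and lower numbers for lower permeability. Compound 1 `CC(C)CC[C@@H](O)C(=O)N1N=CC[C@H]1C(=O)NCc1cc(Cl)ccc1-n1cnnn1` gives 29 10^-6 cm/s, while compound 2 `O=C(NCc1cc(Cl)ccc1-n1cnnn1)[C@@H]1C[C@@H]2C[C@@H]2N1C(=O)[C@H](O)CC1CC1` gives 3.6 10^-6 cm/s and stands at the low end of the three numbers, with compound 3 within the scatter of it and compound 1 beyond. Compound 3 `O=C(NCc1cc(Cl)ccc1-n1cnnn1)[C@@H]1C[C@H]2C[C@H]2N1C(=O)[C@H](O)CC1CC1` gives 6.9 10^-6 cm/s, and the step of a 1.9-fold higher number from compound 2 to compound 3 (0.28 log units; within the scatter) rests on (the fact that compounds 2 and 3 differ only in the configuration as drawn). Compound 4 `O=C(NCc1cc(Cl)ccc1-n1cnnn1)[C@@H]1C[C@@H]2C[C@@H]2N1C(=O)[C@H](O)C1CCCCC1` differs from compound 2 by cyclohexyl in place of cyclopropylmethyl on a saturated chain carbon bound to a carbonyl carbon and an oxygen on a saturated carbon. Going by the values given here, no measured step touches that part of the structure, so the one step available, which stays within the scatter, offers no direct guide. The expected step is therefore a 1.7-fold higher number from compound 2 to compound 4 (0.22 log units; within the scatter), and compound 4 is estimated at 6 10^-6 cm/s, within 2.5 10^-6 cm/s to 14 10^-6 cm/s.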

Compound 4, apparent permeability: 16 10^-6 cm/s
Estimate against measurement, compound 4: 2.7-fold (0.43 log units) below, outside the stated range (above it).
By their numbers in this assay, from the lowest: compounds 2 and 3 (each within the scatter of the next); then compounds 4 and 1 (each within the scatter of the next).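

With cyclohexyl in place of cyclopropylmethyl on a saturated chain carbon bound to a carbonyl carbon and an oxygen on a saturated carbon, this assay shows a 4.4-fold higher number from compound 2 to compound 4 (0.65 log units; beyond the scatter) in this comparison. Unlike the one earlier step, which stayed within the scatter, this step shows that changing this group can shift the read-out beyond it. Nothing available explains the shift. From the compounds shown here alone, it remains open whether the ring or the carbon count matters, and a straight hexyl chain or a piperidine ring here could help separate them.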